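Furan-to-thiophene swap on two cyclic amidine cores

The compounds below may be only part of what the source reports. "The series", "measured", "known", "first", "only" and "open" are said of these compounds alone.

Measured so far in a functional assay on the whole organism (plasma, strain Sprague-Dawley) with Rattus norvegicus as the target, with a stated time of 2 h, at a dose of 100 mg/kg by the oral route; a higher number here means a stronger effect of the compound at the dose given, a lower number a weaker effect:
compound 1 `c1ccc(C(/N=C2\CCCCN2)c2ccco2)cc1` gives 27%
compound 2 `c1ccc(C(/N=C2\CCCCCCN2)c2ccco2)cc1` gives 61%
compound 3 `c1ccc(C(/N=C2\CCCCN2)c2cccs2)cc1` gives 32%

Compound 1 and compound 3 share a core; compound 3 differs by thiophen-2-yl in place of furan-2-yl on a saturated chain carbon bound to an aromatic carbon and a double-bonded nitrogen. That step is a number 5 percentage points higher from compound 1 to compound 3 (within the scatter). Compound 2 carries a different core; how its core differs from that of compound 1 is not broken down here. Compound 2 stands highest of the three, beyond the scatter from both compound 3 and compound 1.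

Compound 4 `c1ccc(C(/N=C2\CCCCCCN2)c2cccs2)cc1` is not yet measured. It differs from compound 2 by thiophen-2-yl in place of furan-2-yl on a saturated chain carbon bound to an aromatic carbon and a double-bonded nitrogen, the same change, at the same place, as from compound 1 to compound 3. Because a number 5 percentage points higher from compound 1 to compound 3 (within the scatter) lies within the scatter, a step of similar size is expected: a number 3 percentage points higher from compound 2 to compound 4 (within the scatter). Compound 4 in this assay is therefore estimated at 64%, expected between 48% and 80%.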

Compound 4, a percentage reported as inhibition, in the whole organism at one dose (the size of the read-out at that dose, not a potency): 41%
For compound 4 the middle estimate is 23 percentage points above the measured one, and the stated range ends above it.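

In this assay, thiophen-2-yl in place of furan-2-yl on the second core gives a number 20 percentage points lower from compound 2 to compound 4 (beyond the scatter). The change therefore does not carry from one core to the other as a step of fixed size and direction: the same change on two cores in this assay, a number 5 percentage points higher (within the scatter) from compound 1 to compound 3 and a number 20 percentage points lower (beyond the scatter) from compound 2 to compound 4, 25 percentage points apart, beyond the scatter of two such steps

This rests on two matched pairs at a single dose, and it does not show why the two steps part or how the change would behave on any further core. The compounds shown leave open how pyridin-2-yl or a simple methyl group would fare on a saturated chain carbon bound to an aromatic carbon and a double-bonded nitrogen, on either core.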